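The source may report more compounds than this note shows. Statements on the series, on what has been measured and on what is new or still open speak of the compounds shown alone.

For the measured compounds named here, compound 1 `Cc1cccc(-c2nnc3c([n+]2[O-])C(C)(C)OC3(C)C)c1` gives 150 mg/kg in a functional assay on the whole organism with Mus musculus as the target (on this read-out lower numbers stand for an effect already at smaller amounts and higher numbers for an effect only at larger amounts of compound), the lower of the two numbers known so far. Compound 2 `CC1(C)OC(C)(C)c2c1nnc(-c1ccc(F)cc1)[n+]2[O-]` gives 500 mg/kg in this assay, and a 3.3-fold higher number from compound 1 to compound 2 (0.52 log units; beyond the scatter). Compound 3 `Cc1ccc(-c2nnc3c([n+]2[O-])C(C)(C)OC3(C)C)cc1C` differs from compound 1 by methyl in place of hydrogen on an aromatic carbon. Going by the values given here, the only measured step, the exchange of one substituted phenyl for another, does not bear on adding a methyl group, so no step beyond the scatter is expected in this assay for compound 3. Compound 3 is therefore estimated at 150 mg/kg, with a range from 60 mg/kg to 400 mg/kg. This expected outcome corresponds to no change at the digits printed from compound 1 to compound 3 (within the scatter).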

Compound 3, dose for half-maximal effect: 133 mg/kg
For compound 3 the middle estimate is 1.1-fold (0.05 log units) above the measured one, and the stated range covers the measured number.
By their numbers in this assay, from the lowest: compounds 3 and 1 (each within the scatter of the next); then compound 2.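

In this assay, methyl in place of hydrogen, on the aromatic carbon ortho to a methyl group and para to a large group, gives a 1.1-fold lower number from compound 1 to compound 3 (0.05 log units; within the scatter). The ring of compound 1 thus takes this added methyl without a step beyond the scatter, which the exchange of one substituted phenyl for another could not show. Nothing at hand bears on why the read-out holds at this position.
Still open, from the compounds shown here alone, is how an amine, a carboxylic acid or a longer chain would read at this carbon. Also open, going by these compounds, is whether the added methyl would read the same on the 4-fluorophenyl ring of compound 2.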